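Swapping the Remaining Fluoro for Chloro on the Halogenated Ring

The compounds below may be only part of what the source reports. "The series", "measured", "known", "first", "only" and "open" are said of these compounds alone.

Compound 1 `O=C(Nc1cccnc1)c1ccccc1OCc1ccccc1F`: 3500 nM
Compound 2 `O=C(Nc1cccnc1)c1ccccc1OCc1c(F)cccc1Cl`: 1500 nM

Both compounds were measured in an assay on lysate for inhibition of phosphatidylcholine:ceramide cholinephosphotransferase 2 (Homo sapiens), read by HPLC, with stated times of 30 min and 2 h; a higher number here means a weaker inhibitor, a lower number a stronger inhibitor. For the measured compounds named here, compound 2 holds the lower of the two numbers; the only measured step, a 2.3-fold lower number from compound 1 to compound 2 (0.37 log units; beyond the scatter), came with chloro entering in place of a hydrogen on an aromatic carbon. Compound 3 `O=C(Nc1cccnc1)c1ccccc1OCc1c(Cl)cccc1Cl` differs from compound 2 by chloro in place of fluoro on an aromatic carbon. Going by the values given here, the one measured step bears on this change only loosely: there, chloro was added where nothing but hydrogen had been, and the number fell modestly; here chloro again enters, but a fluoro leaves at the same time, so the change is smaller in kind. Compound 3 is therefore expected to give about 1000 nM, within a range from 400 nM to 2500 nM. The expected step is a 1.5-fold lower number from compound 2 to compound 3 (0.18 log units; within the scatter), in the lowering direction but likely within the scatter of this assay.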

Compound 3, half-maximal inhibitory concentration: 690 nM
Beside the measured number, compound 3's estimate is 1.4-fold (0.16 log units) above it; the range from low to high includes it.
By their numbers in this assay, from the lowest: compound 3; then compound 2; then compound 1.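

In this assay, exchanging fluoro for chloro on this ring is a real change and not just noise: it gives a 2.2-fold lower number from compound 2 to compound 3 (0.34 log units; beyond the scatter). Until now, only a chloro replacing a hydrogen had been seen to lower the number, and this shows that the remaining fluoro can also be improved on, so that the full change from 2-fluorophenyl to 2,6-dichlorophenyl gives a 5.1-fold lower number from compound 1 to compound 3 (0.71 log units; beyond the scatter). Nothing available here explains why the chloro compounds give the lower numbers.

From the compounds shown here alone, whether a bromo, a methyl or a methoxy group on this same carbon would lower the number further remains open. Also open, going by these compounds, is whether the 2,6-dichlorophenyl group would give a similar gain on a core carrying an amine or a carboxylic acid.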